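Methyl to piperidin-1-yl on the amide side chain

This account rests on a few compounds, and the source may have more. Where it says the series, first, only, none or still open, it means among the compounds named here.

Compound 2 `CCC(=O)Nc1ccc(-c2nc3ccccc3[nH]2)cc1` carries a methyl on a saturated chain carbon bound to a carbonyl carbon. In an ADME assay on BHK cells (Mesocricetus auratus) for cytotoxicity, read by MTT assay, with a stated time of 96 h (on this read-out higher numbers stand for lower toxicity in this test and lower numbers for higher toxicity in this test), compound 2 gives >= 100000 nM, which is a limit of the assay and not a number. Compound 1 `O=C(CN1CCCC1)Nc1ccc(-c2nc3ccccc3[nH]2)cc1` is the nearest measured neighbour; in this assay compound 1 gives 55000 nM. The step of an at least 1.8-fold higher number from compound 1 to compound 2 (0.25 log units; that floor lies within the scatter) is the only measured one that bears on the change in hand, and its floor sits within the scatter. Compound 3 `O=C(CN1CCCCC1)Nc1ccc(-c2nc3ccccc3[nH]2)cc1` is not yet measured. It differs from compound 2 by piperidin-1-yl in place of methyl on a saturated chain carbon bound to a carbonyl carbon, the mirror of the measured step with a larger ring entering. Running that step backwards points, if anywhere, toward a number rather than the limit seen for compound 2 (the limit of >= 100000 nM in this assay, at which 1 of the 2 values shown sits), though any shift would not clearly exceed the scatter. Compound 3 is therefore expected to give 55000 nM, with a range from 20000 nM to 120000 nM. The estimated step of an at least 1.8-fold lower number from compound 2 to compound 3 (0.25 log units; that floor lies within the scatter) rests on compound 1 and its value 55000 nM.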

Compound 3, half-maximal cytotoxic concentration: 31000 nM
For compound 3 the middle estimate is 1.8-fold (0.25 log units) above the measured one; low and high end bracket the measured number.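

In this assay, within the data shown here, piperidin-1-yl in place of methyl on a saturated chain carbon bound to a carbonyl carbon gives an at least 3.2-fold lower number from compound 2 to compound 3 (0.50 log units; beyond the scatter), the only step at this position that clears the scatter, and it points to higher toxicity in this test for compound 3. The ring exchange gives a 1.8-fold lower number from compound 1 to compound 3 (0.25 log units; within the scatter), so piperidin-1-yl and pyrrolidin-1-yl are not separated in this read-out. Compound 2 is a limit of the assay and not a number, which leaves the step from it a floor only: the limit of >= 100000 nM in this assay, at which 1 of the 3 values shown sits.

As far as these compounds go, whether the shift follows the ring or the basic amine nitrogen stays open. A morpholine ring or an open-chain dimethylamine on the same carbon would bear on that question.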